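A few compounds are considered here, and "the series" means these few. Any claim that something is new, unique, unknown or untested is made for them only; others in the source may bear on it.

Measured in a functional assay on the whole organism (Tail, strain ICR) with Mus musculus as the target, in the tail flick test, with a stated time of 30 min, at a dose of 25 umol/kg by the oral route; a higher number here means a stronger effect of the compound at the dose given, a lower number a weaker effect:
compound 1 `O=C(CN(c1nc(Cl)nc2[nH]cnc12)C1CC1)N[C@@H](CC(=O)OCc1ccccc1)C(=O)OCc1ccccc1`: 34.7%
compound 2 `C[C@H](NC(=O)CN(c1nc(Cl)nc2[nH]cnc12)C1CC1)C(=O)O`: 48.1%
compound 3 `CC(C)[C@H](NC(=O)CN(c1ncnc2c1ncn2C1CCCCO1)C1CC1)C(=O)OCc1ccccc1`: 21.8%

Compound 3 stands lowest of the three in this assay; compound 1 is the nearer of the other two and compound 2 the furthest, both lying higher by more than the scatter. Among the measured compounds shown here, no two measured compounds differ in one place only, so no single-change step is available.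

Compound 4 `NC(=O)C[C@H](NC(=O)CN(c1ncnc2c1ncn2C1CCCCO1)C1CC1)C(=O)OCc1ccccc1` differs from compound 3 by carbamoylmethyl in place of isopropyl on a saturated chain carbon bound to an amide-type nitrogen and a carbonyl carbon. For the measured compounds named here, no measured pair shows this change. Compound 1 at 34.7% and compound 2 at 48.1% carry other groups on that carbon, on other cores, and give higher numbers than compound 3; a modest rise in this assay is therefore expected, with a number 6.2 percentage points higher from compound 3 to compound 4 (within the scatter) as the estimated step, which may not exceed the scatter. For compound 4 the expected value in this assay is 28%, ranging from 12% to 45%.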

Compound 4, a percentage reported as activity, at one dose (the size of the read-out at that dose, not a potency): 34.5%
For compound 4 the middle estimate is 6.5 percentage points below the measured one, and the stated range covers the measured number.
By their numbers in this assay, from the lowest: compound 3; then compounds 4 and 1 (each within the scatter of the next); then compound 2.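

Carbamoylmethyl in place of isopropyl on a saturated chain carbon bound to an amide-type nitrogen and a carbonyl carbon gives the only single-place comparison in the series: in this assay the change gives a number 12.7 percentage points higher from compound 3 to compound 4 (beyond the scatter). The read-out at this dose therefore responds to the group at this position on the shared core. Nothing at hand accounts for the step.

From the compounds shown here alone, whether an amine or a hydroxymethyl group on that carbon would shift the number remains open. Also open, going by these compounds, is whether the same change would hold on the core of compound 1.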